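The source may report more compounds than this note shows. Statements on the series, on what has been measured and on what is new or still open speak of the compounds shown alone.

Measured so far in a functional assay on KB cells (Homo sapiens) for antiproliferative activity, read by sulforhodamine B assay, with a stated time of 48 h; a lower number here means a stronger inhibitor of growth, a higher number a weaker inhibitor of growth:
- compound 1 `Nc1ccccc1NC(=O)c1ccc(CCc2ccccc2NS(=O)(=O)c2ccc(Cl)cc2)cc1` gives 448 nM
- compound 2 `Nc1ccccc1NC(=O)c1ccc(CCc2ccccc2NS(=O)(=O)c2ccc(Br)cc2)cc1` gives 124 nM
- compound 3 `COc1ccc(S(=O)(=O)Nc2ccccc2CCc2ccc(C(=O)Nc3ccccc3O)cc2)cc1` gives 472 nM

Compound 3 lies within the scatter of compound 1, and its number is higher than that of compound 2 by more than the scatter.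

Compound 4 `COc1ccc(S(=O)(=O)Nc2ccccc2CCc2ccccc2)cc1` follows from compound 3 by one change: hydrogen in place of (2-hydroxyphenyl)carbamoyl on an aromatic carbon. This puts hydrogen in place of (2-hydroxyphenyl)carbamoyl on an aromatic carbon.

Within the data shown here, the only measured step is a 3.6-fold lower number from compound 1 to compound 2 (0.56 log units; beyond the scatter), a swap of bromo for chloro on an aromatic carbon. Among the measured compounds shown here, it bears on this change only weakly, as no measured compound lacks the carbamoyl group. The size of the new step therefore cannot be read from the data. Since the change removes far more than that halogen swap did, a large step to a higher number, well beyond the scatter, is expected in this assay.

The estimated step is a 25-fold higher number from compound 3 to compound 4 (1.41 log units; beyond the scatter) in this series. For compound 4 the estimated value is 12000 nM, with an expected range from 2500 nM to 50000 nM.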

Compound 4, concentration for 50% growth inhibition: 4410 nM
Estimate against measurement, compound 4: 2.7-fold (0.43 log units) above; low and high end bracket the measured number.
By their numbers in this assay, from the lowest: compound 2; then compounds 1 and 3 (each within the scatter of the next); then compound 4.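

Among these compounds, replacing (2-hydroxyphenyl)carbamoyl on this aromatic carbon with hydrogen gives a 9.3-fold higher number from compound 3 to compound 4 (0.97 log units; beyond the scatter) in this assay, the first reading of what this whole group contributes, as all the earlier compounds carry a carbamoyl group here. The read-out remains a finite number without the group, with compound 4 at 4410 nM, so the sulfonamide half with its plain phenyl end retains measurable growth inhibition in this series. No measured evidence is available to account for the size of this step.

On these data alone, it remains open which part of the departing group carries the step, since a carboxylic acid or a plain phenylcarbamoyl group at this place would separate the carbonyl from the 2-hydroxyphenyl ring. As far as these compounds go, whether removal has a similar effect in the chloro and bromo compounds also remains open.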